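A few compounds are considered here, and "the series" means these few. Any claim that something is new, unique, unknown or untested is made for them only; others in the source may bear on it.

In a functional assay on HEK293 cells for activation of melanin-concentrating hormone receptor 1 (Rattus norvegicus), read by inositol phosphate accumulation (a lower number here means that less compound is needed, a higher number that more compound is needed for the effect), compound 1 `O=C(CCc1ccc(C(F)(F)F)cc1)Nc1ccc2nc(N3CCC(NS(=O)(=O)O)C3)ccc2c1` gives 50 nM, while compound 2 `CC1CCCN1c1ccc2cc(NC(=O)CCc3ccc(C(F)(F)F)cc3)ccc2n1` gives 270 nM. Among the two measured compounds, compound 2 therefore stands at the highest number, its only neighbour being compound 1, and the step of a 5.4-fold higher number from compound 1 to compound 2 (0.73 log units; beyond the scatter) accompanied the exchange of 3-(sulfoamino)pyrrolidin-1-yl for 2-methylpyrrolidin-1-yl on an aromatic carbon. Compound 3 `CN(c1ccc2cc(NC(=O)CCc3ccc(C(F)(F)F)cc3)ccc2n1)C1CCCC1` is not yet measured. It differs from compound 2 by cyclopentyl(methyl)amino in place of 2-methylpyrrolidin-1-yl on an aromatic carbon, the change sitting on an aromatic carbon next to the ring nitrogen of the shared core. Among the measured compounds shown here, no measured step covers this particular exchange; the single step known only shows that altering the amine at this position can move the number by a modest amount. For compound 3 a small upward shift is expected, a 1.3-fold higher number from compound 2 to compound 3 (0.11 log units; within the scatter), so its value in this assay is estimated at 350 nM, with a likely range from 120 nM to 1000 nM.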

Compound 3, half-maximal effective concentration: 350 nM
The estimate for compound 3 equals the measured number at the digits printed; low and high end bracket the measured number.
By their numbers in this assay, from the lowest: compound 1; then compounds 2 and 3 (each within the scatter of the next).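

In this assay, the step of a 1.3-fold higher number from compound 2 to compound 3 (0.11 log units; within the scatter) lies within the scatter, so this assay does not separate cyclopentyl(methyl)amino from 2-methylpyrrolidin-1-yl on this aromatic carbon next to the ring nitrogen, even though the nitrogen of the first group sits outside its carbon-only ring and the nitrogen of the second sits inside its ring. The step of a 7.0-fold higher number from compound 1 to compound 3 (0.85 log units; beyond the scatter) lies beyond the scatter, so among these three compounds, the one with 3-(sulfoamino)pyrrolidin-1-yl stands apart from the two with groups lacking the sulfoamino part. Nothing measured here offers an explanation for either step.

From the compounds shown here alone, it remains open whether the sulfoamino part itself sets compound 1 apart, or whether a carboxylic acid or a primary amine at the same ring carbon of the pyrrolidine would give a similar number. Going by these compounds, how a longer chain between that ring and such a group would read in this assay also remains open.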